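This account rests on a few compounds, and the source may have more. Where it says the series, first, only, none or still open, it means among the compounds named here.

In a functional assay on NCI-H226 cells (Homo sapiens) for inhibition, read by MTT assay, with a stated time of 72 h (on this read-out higher numbers stand for weaker inhibition of growth and lower numbers for stronger inhibition of growth), compound 1, `COC(=O)c1nc(C)n(-c2ccccc2)n1`, gives only a limit, > 100000 nM, and not a number. Compound 2, `COC(=O)c1nc(C)n(-c2cccc(C(F)(F)F)c2)n1`, gives 14300 nM in this assay, and the step of an at least 6.9-fold lower number from compound 1 to compound 2 (0.84 log units; beyond the scatter) shows the change to a trifluoromethyl group. Compound 3, `CCc1nc(C(=O)OC)nn1-c1ccc(F)cc1`, gives 71300 nM in this assay, the highest of the two numbers shown, with compound 2 the nearest and lower, the gap between them lying beyond the scatter. Compound 4, `COC(=O)c1nc(-c2ccc[nH]2)n(-c2ccc(F)cc2)n1`, has not been measured; it differs from compound 3 by 1H-pyrrol-2-yl in place of ethyl on an aromatic carbon, the new group sitting between two ring nitrogen atoms of the shared core. Among the measured compounds shown here, no measured step touches that carbon: the one measured step, an at least 6.9-fold lower number from compound 1 to compound 2 (0.84 log units; beyond the scatter), concerns the phenyl ring and not the group between the two ring nitrogen atoms, so it does not bear on this change. With nothing to guide direction, the expected step of a 1.2-fold lower number from compound 3 to compound 4 (0.07 log units; within the scatter) is one not beyond the scatter. Compound 4 is therefore estimated at 60000 nM in this assay, with a range from 12000 nM to 200000 nM.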

Compound 4, concentration for 50% growth inhibition: 72000 nM
Estimate against measurement, compound 4: 1.2-fold (0.08 log units) below; low and high end bracket the measured number.
By their numbers in this assay, from the lowest: compound 2; then compounds 3 and 4 (each within the scatter of the next). At a limit, above all of these: compound 1.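

In this assay, among the compounds shown here, putting 1H-pyrrol-2-yl in place of ethyl on the aromatic carbon between two ring nitrogen atoms gives a 1.0-fold higher number from compound 3 to compound 4 (0.00 log units; within the scatter), the first reading at this position. In this one pair, the added five-membered aromatic ring and its hydrogen-bond donor leave compound 3 and compound 4 indistinguishable, so the position accepts either group with no detectable gain or loss in growth inhibition. Compound 1 alone stands at a limit, so this step is read between two numbers and not against that limit: the limit of > 100000 nM in this assay, at which 1 of the 4 values shown sits.

As far as these compounds go, whether an amine, a longer chain or a phenyl group on this carbon would shift the number remains open. Also open, from the compounds shown here alone, are whether the same holds with the trifluoromethyl-bearing ring of compound 2, and what a carboxylic acid in place of the methoxycarbonyl group would do.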